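Thiourea series: alkoxy to acyloxy change on the aromatic oxygen

A few compounds are considered here, and "the series" means these few. Any claim that something is new, unique, unknown or untested is made for them only; others in the source may bear on it.

Measured compounds in a functional assay for inhibition of Vanilloid receptor (Rattus norvegicus); a lower number here means a stronger inhibitor, a higher number a weaker inhibitor:
compound 1, `CCCOc1cc(C(C)(C)C)ccc1C/N=C(\S)NCc1ccc(NS(C)(=O)=O)cc1`, 250 nM
compound 2, `COCOc1cc(C(C)(C)C)ccc1C/N=C(\S)NCc1ccc(NS(C)(=O)=O)cc1`, 500 nM

Compound 1 gives the lowest of the two numbers in this assay, but compound 2 sits close to it: a 2.0-fold higher number from compound 1 to compound 2 (0.30 log units; within the scatter). The two values therefore cannot be told apart, and neither compound can be called the stronger inhibitor on these data.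

Compound 3, `CC(C)(C)C(=O)Oc1cc(C(C)(C)C)ccc1C/N=C(\S)NCc1ccc(NS(C)(=O)=O)cc1`, is not yet measured. It differs from compound 1 in one place: (tert-butyl)carbonyl in place of propyl on an oxygen on an aromatic ring. The entering group brings a hydrogen-bond acceptor where propyl had none, and the group on the oxygen grows from three heavy atoms to six.

Within the data shown here, only one measured step bears on this change, and only loosely: the step from compound 1 to compound 2 also replaces part of the group on the same oxygen, and it stayed within the scatter. Among the measured compounds shown here, no measured step introduces a (tert-butyl)carbonyl on this oxygen, so the direction is uncertain. A modest step toward a higher number is expected, with a wide range.

For compound 3 the expected value in this assay is 450 nM, with a range from 150 nM to 1400 nM.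

The step this estimate means, a 1.8-fold higher number from compound 1 to compound 3 (0.26 log units; within the scatter), is an expectation rather than a measurement.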

Compound 3, half-maximal inhibitory concentration: 220 nM
For compound 3 the middle estimate is 2.0-fold (0.31 log units) above the measured one; the measured number falls inside the stated range.
By their numbers in this assay, from the lowest: compounds 3, 1 and 2 (each within the scatter of the next, the first and the last beyond it).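

In this assay, this oxygen on an aromatic ring carries an acyl group as well as an alkyl group without a clear separation in the numbers: (tert-butyl)carbonyl in place of propyl gives a 1.1-fold lower number from compound 1 to compound 3 (0.06 log units; within the scatter). Thus, the entering group's larger heavy-atom count and its hydrogen-bond acceptor come with a value that cannot be told apart from that of the propyl compound. Among these compounds, the same group in place of methoxymethyl gives a 2.3-fold lower number from compound 2 to compound 3 (0.36 log units; beyond the scatter), the first step at this position to pass beyond the scatter, although it is modest and the propyl and methoxymethyl compounds themselves remain within the scatter of each other; nothing available gives a reason for either step.

The contributions of the carbonyl and the tert-butyl part remain inseparable, as the compounds shown include neither a smaller acyl group such as acetyl nor a neopentyl ether on this oxygen. Also open, going by these compounds, is whether a longer chain such as hexyl, or a chain ending in an amine or a carboxylic acid, would stay within this narrow span of values.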